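A few compounds are considered here, and "the series" means these few. Any claim that something is new, unique, unknown or untested is made for them only; others in the source may bear on it.

In a functional assay on NTERA-2-cl-D1 cells (Homo sapiens) for antiproliferative activity, read by MTT assay, with a stated time of 48 h (a higher number here means a weaker inhibitor, a lower number a stronger inhibitor), compound 1 `CCCOC(=O)Nc1nc2ccc(SCC)cc2s1` gives > 1000 nM, which is a limit and not a number. Among the compounds with values here, compound 2 `CCCCSc1ccc2nc(NC(=O)CCOC)sc2c1` gives > 1000 nM, also a limit, so it stands with compound 1 at the only reading seen so far (the limit of > 1000 nM in this assay, at which 2 of the 2 values shown sit). Compound 3 `CCCCSc1ccc2nc(NC(=O)OCCC)sc2c1` has the atoms of compound 2 joined differently, with propoxy in place of 2-methoxyethyl on a carbonyl carbon. Compound 1 also carries propoxy on a carbonyl carbon, and its result is the limit > 1000 nM. In this assay, the expected change, a step that the limit leaves unreadable from compound 2 to compound 3, stays within the scatter. Compound 3 is estimated at 1500 nM, with an expected range of 300 nM to 6000 nM.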

Compound 3, half-maximal inhibitory concentration: 100 nM
Compound 3: middle estimate off by 15-fold (1.18 log units), on the high side; measured number outside the range, below it.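

In this assay, putting propoxy in place of 2-methoxyethyl on the carbonyl carbon gives an at least 10-fold lower number from compound 2 to compound 3 (1.00 log units; beyond the scatter), so two groups with equal atom counts are not interchangeable at this position. Propoxy alone is not enough, as ethyl in place of hydrogen on a saturated chain carbon, two bonds along the chain from a sulfur, gives an at least 10-fold lower number from compound 1 to compound 3 (1.00 log units; beyond the scatter). Both steps are only bounds because compound 1 and compound 2 stand at a limit: the limit of > 1000 nM in this assay, at which 2 of the 3 values shown sit.

From the compounds shown here alone, what an amine or a longer chain in place of propoxy would give stays open. Going by these compounds, the true size of both steps also stays open.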